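Replacing a Phenyl with a Fluorinated Chain in an EP2 Agonist Series

The source may hold more compounds than are shown below. What is called first, only, known or untested is meant among the compounds shown, and "the series" means these compounds.

Measured compounds:
compound 1, `CCOCCC1([C@H](O)/C=C/[C@H]2COC(=O)N2CCSc2nc(C(=O)O)cs2)CCC1`, 29 nM
compound 2, `CCCC[C@H](C)C[C@H](O)/C=C/[C@H]1CCC(=O)N1CCSc1nc(C(=O)O)cs1`, 0.39 nM
compound 3, `O=C(O)c1csc(SCCN2C(=O)OC[C@@H]2/C=C/[C@@H](O)C2(CCc3ccccc3)CCC2)n1`, 160 nM

The measurements come from an assay on isolated protein for agonist activity at prostaglandin E2 receptor EP2 subtype (Homo sapiens); a lower number here means that less compound is needed, a higher number that more compound is needed for the effect. Among the three measured compounds, compound 3 gives the highest number, so it needs the most material for the effect; its nearest neighbour is compound 1, and compound 2 lies furthest away from it.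

Compound 4, `O=C(O)c1csc(SCCN2C(=O)OC[C@@H]2/C=C/[C@@H](O)C2(CCCCF)CCC2)n1`, has not yet been measured. Compared with compound 3 it carries 2-fluoroethyl in place of phenyl on a saturated chain carbon, two bonds along the chain from a saturated ring carbon. This 2-fluoroethyl group is a short chain with no ring.

Within the data shown here, only one measured step touches the same position: the step from the ethoxy of compound 1 to the phenyl of compound 3, which gave a 5.5-fold higher number from compound 1 to compound 3 (0.74 log units; beyond the scatter). Going the other way, from the phenyl back toward a small open chain, the number is expected to move down again, though the 2-fluoroethyl chain is not the ethoxy of compound 1, so the return may be incomplete. For compound 4 the expected step is a 3.2-fold lower number from compound 3 to compound 4 (0.51 log units; beyond the scatter). Compound 4 is therefore estimated at 50 nM, with a range from 12 nM to 200 nM.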

Compound 4, half-maximal effective concentration: 2.9 nM
Compound 4: the middle estimate sits 17-fold (1.24 log units) above what was measured; measured number outside the range, below it.
By their numbers in this assay, from the lowest: compound 2; then compound 4; then compound 1; then compound 3.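

In this assay the end of this side chain matters more than the earlier pair suggested: exchanging the phenyl for 2-fluoroethyl gives a 55-fold lower number from compound 3 to compound 4 (1.74 log units; beyond the scatter) and so outweighs the earlier step of a 5.5-fold higher number from compound 1 to compound 3 (0.74 log units; beyond the scatter) in size. The ring-free fluorinated chain does more than recover what the phenyl lost, since it also improves on the ethoxy chain, with a 10-fold lower number from compound 1 to compound 4 (1.00 log units; beyond the scatter) as the result.

As far as these compounds go, the role of the fluorine itself remains open, and a plain propyl or butyl chain at this place would help separate it from the effect of chain length. Compound 2 differs from compound 4 in more than one place, so the gap between them cannot be assigned to any single change. No measurement shown here offers an explanation for these steps.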